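Swapping an aromatic arm for a propyl chain

A few compounds are considered here, and "the series" means these few. Any claim that something is new, unique, unknown or untested is made for them only; others in the source may bear on it.

Measured compounds:
compound 1 `Oc1ccc(C(c2c[nH]c3ccc(Br)cc23)c2c[nH]c3ccc(Br)cc23)cc1` 9000 nM
compound 2 `COc1ccc(C(c2c[nH]c3ccc(Br)cc23)c2c[nH]c3ccc(Br)cc23)c(OC)c1` 100000 nM

Within the data shown here, in a functional assay on A549 cells (Homo sapiens) for inhibition, read by MTT assay, with a stated time of 48 h (a lower number here means a stronger inhibitor, a higher number a weaker inhibitor), compound 2 gives the higher of the two numbers so far, with compound 1 the only neighbour, an 11-fold higher number from compound 1 to compound 2 (1.05 log units; beyond the scatter) below it. Compound 3 `CCCC(c1c[nH]c2ccc(Br)cc12)c1c[nH]c2ccc(Br)cc12` has not yet been measured; it arises from compound 2 through (propyl in place of 2,4-dimethoxyphenyl on a saturated chain carbon bound to two aromatic carbons). Among the measured compounds shown here, the one measured step touches the same position, an 11-fold higher number from compound 1 to compound 2 (1.05 log units; beyond the scatter), and shows that the group on this carbon can shift the number strongly, but it compares two aromatic arms, not an aromatic arm against a chain, so no step here tells directly what propyl does. The expectation is therefore wide: compound 3 is estimated to sit near compound 2, with a step of a 2.0-fold lower number from compound 2 to compound 3 (0.30 log units; within the scatter) in this assay, and its value is estimated at 50000 nM, within a range from 10000 nM to 200000 nM.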

Compound 3, half-maximal inhibitory concentration: 6500 nM
The estimate for compound 3 lay 7.7-fold (0.89 log units) above the measured number; the whole stated range lies above it.
By their numbers in this assay, from the lowest: compounds 3 and 1 (each within the scatter of the next); then compound 2.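

In this assay, an aromatic arm on this saturated chain carbon proves not to be required: propyl, which has no ring, brings a 15-fold lower number from compound 2 to compound 3 (1.19 log units; beyond the scatter), and there is a 1.4-fold lower number from compound 1 to compound 3 (0.14 log units; within the scatter), so the two values cannot be told apart. The earlier step compared only two aromatic arms, whereas these three compounds now show that the 2,4-dimethoxyphenyl compound alone stands apart, and that a chain can match the 4-hydroxyphenyl arm. Nothing available explains why this is so.

From the compounds shown here alone, it remains open whether propyl is a special case or whether a shorter chain such as ethyl, or a longer one such as hexyl, would give a similar number. A plain phenyl arm would also help show whether the 4-hydroxyphenyl compound owes its number to its hydroxyl group or to the ring itself.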